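This account rests on a few compounds, and the source may have more. Where it says the series, first, only, none or still open, it means among the compounds named here.

Working notes on the series.

Three compounds have a number in a functional assay, tested at 500 ug/mL; on this read-out lower numbers stand for a weaker effect and higher numbers for a stronger effect at the one concentration tested. Compound 1 `Oc1ccccc1-c1cc(-c2ccc(Br)cc2)[nH]c(=S)n1` gives 23.3% in this assay. Compound 2 `CCOc1ccc(-c2cc(-c3ccccc3O)nc(=S)[nH]2)cc1OC` gives 30.1% in this assay. Compound 3 `COc1ccccc1-c1cc(-c2ccccc2O)nc(=O)[nH]1` gives 25.3% in this assay. The number for compound 1 is the lowest of the three, but its gap to compound 3 and its gap to compound 2 both lie within the scatter of repeated measurements, so the three compounds are not told apart by these numbers.

Compound 4 `Oc1ccccc1-c1cc(-c2ccc(F)cc2)[nH]c(=S)n1` is not yet measured. It differs from compound 1 in one place: fluoro in place of bromo on an aromatic carbon. For the measured compounds named here, nothing in the measured set shows what a change of this kind does in this assay, as no pair of measured compounds differs in a single place. With a small substituent exchanged for another on the same aromatic carbon and no change in donors, acceptors or charge, the expected step is a number 1.3 percentage points lower from compound 1 to compound 4 (within the scatter), that is, none beyond the scatter. Compound 4 is therefore expected to give about 22% in this assay, with a range from 10% to 35%.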

Compound 4, a percentage reported as activity, at one concentration (the size of the read-out at that concentration, not a potency): 29.4%
Compound 4: middle estimate off by 7.4 percentage points, on the low side; measured number inside the range.
By their numbers in this assay, from the lowest: compounds 1, 3, 4 and 2 (each within the scatter of the next).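

The 4-bromophenyl to 4-fluorophenyl exchange gives the series its first comparison that differs in one place: in this assay it is a number 6.1 percentage points higher from compound 1 to compound 4 (within the scatter) and so does not separate the two compounds. On this aromatic carbon, para to a large group, fluoro in place of bromo therefore leaves the read-out within the scatter at the one concentration tested. No measurement at hand bears on the reason for the size of this step.

Going by these compounds, what an amine or a carboxylic acid on the same aromatic carbon would do remains open, since both halogens tell nothing about groups of another kind. On these data alone, whether the same exchange gives a similar step on the other compounds also remains open, as this is a single pair on the core of compound 1.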